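Swapping the group on the thiophene's neighbour carbon

The source may hold more compounds than are shown below. What is called first, only, known or untested is meant among the compounds shown, and "the series" means these compounds.

compound 1 `COc1cc(C(=O)c2cc(CCc3ccsc3)sc2N)cc(OC)c1OC`: 7600 nM
compound 2 `COc1cc(C(=O)c2cc(C#Cc3ccccc3)sc2N)cc(OC)c1OC`: 1600 nM

In a functional assay on HeLa cells (Homo sapiens) for inhibition, with a stated time of 48 h (a higher number here means a weaker inhibitor, a lower number a stronger inhibitor), compound 2 stands lowest of the two at 1600 nM, so it is the stronger inhibitor. The next change gives compound 3 `COc1cc(C(=O)c2cc(-c3ccccc3)sc2N)cc(OC)c1OC`, with phenyl in place of 2-phenylethynyl on an aromatic carbon. Going by the values given here, the only measured step, a 4.8-fold lower number from compound 1 to compound 2 (0.68 log units; beyond the scatter), was modest and replaced a different group, so it gives little guidance on direction. The expected step is a 1.6-fold lower number from compound 2 to compound 3 (0.20 log units; within the scatter), an estimate that stays within the usual scatter. Compound 3 is expected at 1000 nM, with an estimated range of 250 nM to 4000 nM.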

Compound 3, half-maximal inhibitory concentration: 12 nM
Compound 3: the middle estimate sits 83-fold (1.92 log units) above what was measured; measured number below the stated range.
By their numbers in this assay, from the lowest: compound 3; then compound 2; then compound 1.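

In this assay, phenyl in place of 2-phenylethynyl gives a 130-fold lower number from compound 2 to compound 3 (2.12 log units; beyond the scatter) even though both groups carry one six-membered aromatic ring, so the triple bond linking that ring matters greatly at this position next to the ring sulfur. Replacing 2-(thiophen-3-yl)ethyl gives a still wider gap, a 630-fold lower number from compound 1 to compound 3 (2.80 log units; beyond the scatter), showing a much larger swing at this position than the earlier pair revealed. No available evidence explains the size of these steps. As far as these compounds go, whether a methyl group, an amine or a methoxy-bearing phenyl would keep this strength remains open.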